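This account rests on a few compounds, and the source may have more. Where it says the series, first, only, none or still open, it means among the compounds named here.

Compound 1 `COc1ccc(Oc2ccccc2-c2ccsc2S(=O)(=O)N2CCN(C(=O)Nc3cccc([N+](=O)[O-])c3)CC2)cc1OC` reads > 50000 nM in a functional assay on HeLa cells (Homo sapiens) for inhibition, read by CCK-8 assay, with a stated time of 48 h (a lower number here means a stronger inhibitor, a higher number a weaker inhibitor), and this is a limit of the assay, not a number. Compound 1 therefore stands at the limit of > 50000 nM in this assay, at which 1 of the 3 values shown sits. The other two measured compounds do return numbers: compound 2 `O=[N+]([O-])c1cccc(NC(=S)NCCNS(=O)(=O)c2ccc(-c3ccccc3OCc3cccc(O)c3)s2)c1` gives 11100 nM, and compound 3 `O=C(NCCNS(=O)(=O)c1ccc(-c2ccccc2O[C@H]2CC[C@@H](O)CC2)s1)Nc1cc(C(F)(F)F)cc(C(F)(F)F)c1` gives 14100 nM. These two values lie within the usual scatter of each other. Neither compound carries the core of compound 1, so they offer only a loose frame for what follows.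

Compound 4 `COc1ccc(Oc2ccccc2-c2ccsc2S(=O)(=O)N2CCN(C(=O)Nc3ccc(F)cc3)CC2)cc1OC` keeps that core and differs in one place: 4-fluorophenyl in place of 3-nitrophenyl on an amide-type nitrogen. In words, 4-fluorophenyl stands in place of 3-nitrophenyl on an amide-type nitrogen. Going by the values given here, no measured pair in this set shows what such an exchange does in this assay. The expectation for compound 4 therefore rests on compound 1, which has the same core, at its limit > 50000 nM. The step expected an at least 1.1-fold lower number from compound 1 to compound 4 (0.04 log units; that floor lies within the scatter) stays within the scatter, so no clear change in either direction is estimated. For compound 4 the estimated half-maximal inhibitory concentration is 45000 nM, with an expected range of 20000 nM to 100000 nM, and a further reading at the limit would be no surprise.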

Compound 4, half-maximal inhibitory concentration: > 20000 nM
Compound 4: no number, only a limit; the forecaster's own chance of this, stated with the estimate: 60%; the middle value does not contradict the limit.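

In this assay compound 4 gives > 20000 nM, which is a limit of the assay and not a number. Compound 1 also reads only as a limit, and no step can be read between compound 1 and compound 4. The compounds shown leave open what 4-fluorophenyl in place of 3-nitrophenyl on an amide-type nitrogen does in this assay.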